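Furan regiochemistry on two nucleoside cores

A few compounds are considered here, and "the series" means these few. Any claim that something is new, unique, unknown or untested is made for them only; others in the source may bear on it.

Compound 1 `O=c1[nH]cnc2c1c(-c1ccoc1)cn2[C@@H]1O[C@H](CO)[C@@H](O)[C@H]1O` and compound 2 `O=c1[nH]cnc2c1c(-c1ccco1)cn2[C@@H]1O[C@H](CO)[C@@H](O)[C@H]1O` share one core and differ only in the furan: furan-2-yl in place of furan-3-yl on an aromatic carbon. In a functional assay on HL-60 cells (Homo sapiens) for antiproliferative activity, read by XTT assay, with a stated time of 72 h (on this read-out lower numbers stand for stronger inhibition and higher numbers for weaker inhibition), compound 1 gives 6370 nM, while compound 2 gives 2200 nM, a step of a 2.9-fold lower number from compound 1 to compound 2 (0.46 log units; beyond the scatter). Compound 3 `COc1nc(N)nc2c1c(-c1ccoc1)cn2[C@@H]1O[C@H](CO)[C@@H](O)[C@H]1O` carries a different core; how the two cores differ is not broken down here. In this assay compound 3 gives > 20000 nM, which is a limit of the assay and not a number (the limit of > 20000 nM in this assay, at which 1 of the 3 values shown sits). Compound 4 `COc1nc(N)nc2c1c(-c1ccco1)cn2[C@@H]1O[C@H](CO)[C@@H](O)[C@H]1O` is still to be measured; it is made from compound 3 by the same change, (furan-2-yl in place of furan-3-yl on an aromatic carbon), at the same place. A step like the measured one, a 2.9-fold lower number from compound 1 to compound 2 (0.46 log units; beyond the scatter), is expected for compound 4: an at least 1.3-fold lower number from compound 3 to compound 4 (0.12 log units; that floor lies within the scatter). Because compound 3 shows only a limit (the limit of > 20000 nM in this assay, at which 1 of the 3 values shown sits), the starting point is itself open. Compound 4 is estimated at 15000 nM, expected between 5000 nM and 60000 nM.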

Compound 4, half-maximal inhibitory concentration: > 20000 nM
Compound 4: only a limit was reported; the forecaster's own chance of this, stated with the estimate: 55%; middle value at least 1.3-fold (0.12 log units) away from the limit.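

Compound 3 and compound 4 both stand at a limit of the assay and not at a number, so no step between them can be read: the limit of > 20000 nM in this assay, at which 2 of the 4 values shown sit.

As far as these compounds go, whether furan-2-yl in place of furan-3-yl acts on the core of compound 3 as it does on the core of compound 1 stays open.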